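Benzoyl to phenylsulfonyl on the shared core

The source may hold more compounds than are shown below. What is called first, only, known or untested is meant among the compounds shown, and "the series" means these compounds.

Three compounds of the series have numbers in a functional assay on TK-10 cells (Homo sapiens) for inhibition, read by sulforhodamine B assay, with a stated time of 48 h; a lower number here means a stronger inhibitor of growth, a higher number a weaker inhibitor of growth. Compound 1, `N#C/C(=C\c1c(-c2ccccc2)[nH]c2ccccc12)C(=O)c1ccccc1`, gives 11100 nM in this assay. Compound 2, `CCOC(=O)C(=Cc1c(-c2ccccc2)[nH]c2ccccc12)C(=O)OCC`, gives 13600 nM in this assay, and compound 3, `COc1ccc2[nH]c(-c3ccccc3)c(/C=C(\C#N)S(=O)(=O)c3ccccc3)c2c1`, gives 17500 nM in this assay. Compound 1 holds the lowest of the three numbers, yet its gaps to compound 2 and to compound 3 both fall within the usual scatter, so no order among the three can be read from these values. Going by the values given here, none of the three pairs differs in one place only, so no single-point step is available from the measured set.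

Compound 4, `N#C/C(=C\c1c(-c2ccccc2)[nH]c2ccccc12)S(=O)(=O)c1ccccc1`, has not yet been measured. It differs from compound 1 in one place: phenylsulfonyl in place of benzoyl on a double-bonded chain carbon bound to a double-bonded chain carbon and a triple-bonded carbon. Among the compounds with values here, no measured pair isolates this exchange. Compound 3 carries the phenylsulfonyl group and the nitrile found in compound 4, but on a differently substituted core, so compound 3 with its value of 17500 nM serves only as a loose guide.

The step from compound 1 to compound 4 is expected to be small, with no direction beyond the scatter, as a 1.3-fold higher number from compound 1 to compound 4 (0.10 log units; within the scatter). Compound 4 is estimated to give 14000 nM in this assay, with a range from 7000 nM to 28000 nM.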

Compound 4, concentration for 50% growth inhibition: 5600 nM
For compound 4 the middle estimate is 2.5-fold (0.40 log units) above the measured one; measured number below the stated range.
By their numbers in this assay, from the lowest: compounds 4, 1, 2 and 3 (each within the scatter of the next, the first and the last beyond it).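

Phenylsulfonyl in place of benzoyl on a double-bonded chain carbon bound to a double-bonded chain carbon and a triple-bonded carbon now has a direct reading in this assay (a 2.0-fold lower number from compound 1 to compound 4 (0.30 log units; within the scatter)), so on the shared core these two groups are not separated at this place. Going by these compounds alone, the only step beyond the scatter lies on the core instead: with phenylsulfonyl and nitrile held fixed, hydrogen in place of methoxy on an aromatic carbon gives a 3.1-fold lower number from compound 3 to compound 4 (0.49 log units; beyond the scatter), a modest step resting on this single pair. The compounds shown offer no independent measurement that would account for either step.

From the compounds shown here alone, whether the methoxy step carries over to the benzoyl group of compound 1 or to the ester groups of compound 2 stays open, since it is read only with phenylsulfonyl on the chain. Also open, going by these compounds, is what a carboxylic acid, an amide or a longer chain ending in an amine would do in place of phenylsulfonyl on that chain carbon, and what fluorine or hydroxy would do in place of hydrogen on that aromatic carbon.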